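This account rests on a few compounds, and the source may have more. Where it says the series, first, only, none or still open, it means among the compounds named here.

Compound 1 `NC(=O)Cc1cc(Br)c(O)c(Br)c1` and compound 2 `CC(=O)Oc1c(Br)cc(CC(N)=O)cc1Br` share one core and differ at a single oxygen on the aromatic ring. In a functional assay on PC-3 cells (Homo sapiens), read by wound healing assay, with a stated time of 24 h (a lower number here means a stronger inhibitor, a higher number a weaker inhibitor), compound 1 gives > 100000 nM, which is a limit of the assay and not a number. In this assay, for the measured compounds named here, compound 2 gives 74800 nM, the only number recorded so far. The step of an at least 1.3-fold lower number from compound 1 to compound 2 (0.12 log units; that floor lies within the scatter) goes with acetyl in place of hydrogen on an oxygen on an aromatic ring. Its floor is set by the limit of > 100000 nM in this assay, at which 1 of the 2 values shown sits. Compound 3 `NC(=O)Cc1cc(Br)c(OC(=O)c2ccccc2)c(Br)c1` is not yet measured and differs from compound 2 by phenyl in place of methyl on a carbonyl carbon. Going by the values given here, only the step from compound 1 to compound 2 bears on this change, and it cannot be placed beyond the scatter, so no step beyond the scatter is expected in this assay. The expected step is a 1.2-fold lower number from compound 2 to compound 3 (0.10 log units; within the scatter). Compound 3 is estimated at 60000 nM, between 15000 nM and 200000 nM.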

Compound 3, half-maximal inhibitory concentration: 12200 nM
Compound 3: middle estimate off by 4.9-fold (0.69 log units), on the high side; measured number below the stated range.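

In this assay, phenyl in place of methyl on a carbonyl carbon gives a 6.1-fold lower number from compound 2 to compound 3 (0.79 log units; beyond the scatter), so the group carried on this carbonyl carbon can move the number beyond the scatter. Compound 1 gives > 100000 nM, which is a limit and not a number. The earlier step at this oxygen therefore offered only a floor within the scatter, and no size could be read from it: the limit of > 100000 nM in this assay, at which 1 of the 3 values shown sits.

With a single replacement, the compounds shown do not tell whether the step goes with the aromatic ring or with the added carbons alone; a cyclohexyl group or a longer chain on the same carbonyl carbon would bear on that. They also leave open how a phenyl carrying a chlorine or a methoxy group would read in this assay.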